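A few compounds are considered here, and "the series" means these few. Any claim that something is new, unique, unknown or untested is made for them only; others in the source may bear on it.

The measured compounds:

- compound 1, `COc1ccc(-c2nc(C)c(C(=O)CSc3nc(-c4ccc(Cl)cc4)c(C#N)c(=O)[nH]3)s2)cc1`, with 63000 nM
- compound 3, `COc1ccc(-c2nc(C)c(C(=O)CSc3nc(-c4ccc(Cl)c(Cl)c4)c(C#N)c(=O)[nH]3)s2)cc1`, with 45600 nM
- compound 2, `Cc1nc(-c2ccccc2)sc1C(=O)CSc1nc(N)c(C#N)c(-c2ccc(Cl)cc2)n1`, with "not determined" (no result reported), so no result was reported for it

These three compounds were tested in an ADME assay on HEK293 cells (Homo sapiens) for cytotoxicity, read by MTT assay, with a stated time of 48 h; a lower number here means a stronger inhibitor, a higher number a weaker inhibitor. Compound 1 and compound 3 share a core and differ in one place: chloro in place of hydrogen on an aromatic carbon. That change gave a 1.4-fold lower number from compound 1 to compound 3 (0.14 log units; within the scatter), so in this assay the two compounds cannot be told apart.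

Compound 2 has a different core, and the difference between the two cores is not broken down here. Compound 4, `Cc1nc(-c2ccc(Cl)cc2)sc1C(=O)CSc1nc(N)c(C#N)c(-c2ccc(Cl)cc2)n1`, has not yet been measured. It differs from compound 2 in one place: chloro in place of hydrogen on an aromatic carbon. Going by the values given here, this is the same kind of change as the one from compound 1 to compound 3, but not the same. In compound 3 the entering chloro sits ortho to a chloro group and meta to a large group, while in compound 4 it sits para to a large group, with no neighbouring chloro.

Compound 2 has no number in this assay. Among the compounds with values here, no step from compound 2 to compound 4 can therefore be sized. The expectation for compound 4 rests only on the flat step from compound 1 to compound 3, a 1.4-fold lower number from compound 1 to compound 3 (0.14 log units; within the scatter), which suggests that adding a chloro group changes little. For compound 4 in this assay a value of about 50000 nM is expected, estimated to fall between 15000 nM and 150000 nM.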

Compound 4, half-maximal inhibitory concentration: 73000 nM
Estimate against measurement, compound 4: 1.5-fold (0.16 log units) below, within the range that was stated.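

In this assay, going by these compounds alone, compound 4 gives 73000 nM while compound 2 has no reported number, so no step from compound 2 to compound 4 can be read. On these data alone, what the change from phenyl to 4-chlorophenyl does on the core of compound 2 therefore stays open in this assay. No supporting data are available here to explain the value of compound 4.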